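The compounds below may be only part of what the source reports. "The series", "measured", "known", "first", "only" and "open" are said of these compounds alone.

Measured so far:
compound 1 `COc1ccc2nc(NC(=O)c3cn(-c4ccccc4)nc3-c3ccccc3)sc2c1`: > 50000 nM
compound 2 `O=C(Nc1nc2ccc(F)cc2s1)c1cn(-c2ccccc2)nc1-c1ccc(F)cc1`: 6650 nM

In a functional assay on A549 cells (Homo sapiens) for cytotoxicity, read by MTT assay, with a stated time of 72 h (a higher number here means a weaker inhibitor, a lower number a stronger inhibitor), compound 1 gives only a limit, > 50000 nM, which is the limit of > 50000 nM in this assay, at which 1 of the 2 values shown sits. Compound 2 gives 6650 nM in this assay, the only true number shown so far. Compound 3 `COc1ccc2nc(NC(=O)c3cn(-c4ccccc4)nc3-c3ccc(F)cc3)sc2c1` differs from compound 2 by methoxy in place of fluoro on an aromatic carbon. Within the data shown here, no measured pair shows this change on its own, so the expected step from compound 2 to compound 3 is a 3.0-fold higher number from compound 2 to compound 3 (0.48 log units; beyond the scatter), a weakening of inhibition beyond the usual scatter. Compound 3 is therefore expected at 20000 nM, with a range from 5000 nM to 80000 nM.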

Compound 3, half-maximal inhibitory concentration: > 50000 nM
Compound 3 ended at the assay's limit; the forecaster's own chance of this, stated with the estimate: 40%; middle value at least 2.5-fold (0.39 log units) from the limit.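

In this assay, among these compounds, methoxy in place of fluoro on this aromatic carbon, now seen as the only change between two compounds, gives an at least 7.5-fold higher number from compound 2 to compound 3 (0.87 log units; beyond the scatter); compound 1 and compound 2 differ in two places and could not isolate it. That size is only a minimum, because the true value of compound 3 lies out of reach: the limit of > 50000 nM in this assay, at which 2 of the 3 values shown sit. The step for fluoro in place of hydrogen between compound 1 and compound 3 cannot be read, as both values are limits.

On these data alone, how a chloro group or an amine at this position would compare remains open. So does how far compound 3 lies past its limit.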